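The source may report more compounds than this note shows. Statements on the series, on what has been measured and on what is new or still open speak of the compounds shown alone.

The measured compounds, in a functional assay on HCT-15 cells (Homo sapiens) for cytotoxicity, read by CCK-8 assay; on this read-out higher numbers stand for weaker inhibition and lower numbers for stronger inhibition:

Compound 1, `Oc1cccc(-c2cc(-c3ccsc3)cc(-c3cccc(O)c3)n2)c1`, gives 1630 nM.
Compound 2, `Oc1ccc(-c2cc(-c3ccsc3)cc(-c3cccc(O)c3)n2)cc1`, gives 1180 nM.
Compound 3, `Oc1cccc(-c2cc(-c3ccccn3)cc(-c3cccc(O)c3)n2)c1`, gives 3510 nM.

Compound 4, `Oc1ccc(-c2cc(-c3ccccn3)cc(-c3cccc(O)c3)n2)cc1`, has not yet been measured in this assay. It is reached from compound 3 by one change, (4-hydroxyphenyl in place of 3-hydroxyphenyl on an aromatic carbon). The same change has been made once before among these compounds, from compound 1 to compound 2, where it is described as 4-hydroxyphenyl in place of 3-hydroxyphenyl on an aromatic carbon and gave a 1.4-fold lower number from compound 1 to compound 2 (0.14 log units; within the scatter). The two cores on which the change is made are not the same: compound 3 differs from compound 1 by pyridin-2-yl in place of thiophen-3-yl on an aromatic carbon, a change that by itself produced a 2.2-fold higher number from compound 1 to compound 3 (0.33 log units; beyond the scatter) and left compound 3 with the highest number of the three, beyond the scatter from both compound 1 and compound 2. Around the place of the change, the two cases also differ in their surroundings: in the first case the carbon is meta to a thiophen-3-yl group, in the second it is meta to a pyridin-2-yl group, so the change in compound 4 is of the same kind as the earlier one rather than the same.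

Going by the values given here, with only one earlier instance to go on, and that instance within the scatter, the expected step from compound 3 to compound 4 is small, about a 1.4-fold lower number from compound 3 to compound 4 (0.15 log units; within the scatter), resting on the earlier step of a 1.4-fold lower number from compound 1 to compound 2 (0.14 log units; within the scatter) and on the value of compound 3, 3510 nM. Compound 4 is therefore expected to give about 2500 nM, estimated to fall between 1400 nM and 4500 nM.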

Compound 4, half-maximal inhibitory concentration: > 50000 nM
Compound 4 ended at the assay's limit (the forecaster's own chance of this, stated with the estimate: 5%); middle value at least 20-fold (1.30 log units) away from the limit.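

In this assay, compound 4 gives > 50000 nM, which is a limit of the assay and not a number. The change to 4-hydroxyphenyl in place of 3-hydroxyphenyl gave an at least 14-fold higher number from compound 3 to compound 4 (1.15 log units; beyond the scatter), so what it did on the core of compound 1 did not carry over to the core of compound 3: the same change on two cores in this assay, a 1.4-fold lower number (0.14 log units; within the scatter) from compound 1 to compound 2 and an at least 14-fold higher number (1.15 log units; beyond the scatter) from compound 3 to compound 4, at least 19-fold (1.29 log units) apart, beyond the scatter of two such steps Read the other way, pyridin-2-yl in place of thiophen-3-yl gave an at least 42-fold higher number from compound 2 to compound 4 (1.62 log units; beyond the scatter), so in these four compounds the two changes do not act independently of each other, although a single pair of cores gives no rule for the series and, with compound 4 at a limit, the true size of the gap stays unknown: the same change on two cores in this assay, a 2.2-fold higher number (0.33 log units; beyond the scatter) from compound 1 to compound 3 and an at least 42-fold higher number (1.62 log units; beyond the scatter) from compound 2 to compound 4, at least 19-fold (1.29 log units) apart, beyond the scatter of two such steps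

The compounds shown leave open whether this large step belongs only to the pairing of the pyridin-2-yl group with the 4-hydroxyphenyl group or would appear with other groups in the same places. A pyridin-3-yl group in place of the pyridin-2-yl group, or a methoxyphenyl group in place of the 4-hydroxyphenyl group, would help to separate these possibilities.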